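Aryl-to-methyl swap on the thiazole-hydrazone series

The compounds below may be only part of what the source reports. "The series", "measured", "known", "first", "only" and "open" are said of these compounds alone.

Measured so far:
compound 1 `C/C(=N\Nc1nc(-c2ccccc2)cs1)c1cc2ccccc2o1` — 11700 nM
compound 2 `C/C(=N\Nc1nc(-c2cc3ccccc3o2)cs1)c1cc2ccccc2o1` — 24100 nM

In a functional assay on HeLa cells (Homo sapiens) for antiproliferative activity (on this read-out lower numbers stand for stronger inhibition and higher numbers for weaker inhibition), compound 1 gives 11700 nM and compound 2 gives 24100 nM. Compound 2 stands at the highest of the two numbers; its nearest neighbour is compound 1, and the step of a 2.1-fold higher number from compound 1 to compound 2 (0.31 log units; beyond the scatter) is modest but beyond the scatter.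

Compound 3 `C/C(=N\Nc1nc(C)cs1)c1cc2ccccc2o1` is not yet measured. It differs from compound 2 in one place: methyl in place of 1-benzofuran-2-yl on an aromatic carbon. Going by the values given here, the only measured step that bears on this position is a 2.1-fold higher number from compound 1 to compound 2 (0.31 log units; beyond the scatter), where the larger group raised the number. The change to compound 3 removes that large group entirely and leaves only a methyl, which goes further than the reverse of the measured step. On that single step, a number at or somewhat below that of compound 2 is expected, but the data give no guide for a group as small as methyl here, so the range is kept wide. Compound 3 is therefore estimated at 12000 nM (range 4000 nM to 40000 nM), a step of a 2.0-fold lower number from compound 2 to compound 3 (0.30 log units; within the scatter).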

Compound 3, half-maximal inhibitory concentration: 8970 nM
For compound 3 the middle estimate is 1.3-fold (0.13 log units) above the measured one; measured number inside the range.
By their numbers in this assay, from the lowest: compounds 3 and 1 (each within the scatter of the next); then compound 2.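

In this assay, methyl in place of 1-benzofuran-2-yl on the aromatic carbon next to the ring nitrogen gives a 2.7-fold lower number from compound 2 to compound 3 (0.43 log units; beyond the scatter) and is beyond the scatter, so a ring-bearing group at this position is not required to hold the read-out at the level of compound 3. Methyl in place of phenyl gives a 1.3-fold lower number from compound 1 to compound 3 (0.12 log units; within the scatter) and is within the scatter, so the series so far does not separate phenyl from methyl here, even though one brings an aromatic ring and the other no ring at all; of the three groups, only 1-benzofuran-2-yl stands apart, and compound 2 lies beyond the scatter from both compound 1 and compound 3. Nothing among the available data accounts for this difference between the groups.

Still open, from the compounds shown here alone, is whether an amine, a carboxylic acid or a longer alkyl chain at this position would move the number away from the level shared by compound 1 and compound 3. Going by these compounds, the second 1-benzofuran-2-yl group is held constant in all three compounds, so the effect of replacing it with a phenyl or a methyl also remains unknown.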